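Quaternary tail series: methyl to ethyl on the ring nitrogen

The source may hold more compounds than are shown below. What is called first, only, known or untested is meant among the compounds shown, and "the series" means these compounds.

Measured in an assay on LX2 cells for inhibition of COL1A1 promoter (Homo sapiens), read by a luciferase reporter, with a stated time of 24 h, tested at 20 uM; a lower number here means a weaker effect, a higher number a stronger effect of the compound at the concentration tested:
compound 1 `Cc1ccc(-n2cc(C(=O)Nc3cc(F)cc(F)c3)c(=O)c3ccc(N(C)C)nc32)cc1OCCCCCCC[N+]12CCN(CC1)CC2` gives 5.07%
compound 2 `Cc1cc(OCCCCCCC[N+]2(C)CCCC2)cc(-n2cc(C(=O)Nc3cc(F)cc(F)c3)c(=O)c3ccc(N(C)C)nc32)c1` gives 4.32%
compound 3 `Cc1cc(OCCCCCCC[N+]2(C)CCCCC2)cc(-n2cc(C(=O)Nc3cc(F)cc(F)c3)c(=O)c3ccc(N(C)C)nc32)c1` gives 46.8%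

Compound 3 stands highest of the three values, beyond the scatter from compound 1 and from compound 2. Going by the values given here, the only step measured in one place, a number 42.5 percentage points higher from compound 2 to compound 3 (beyond the scatter), concerns the ring on the chain nitrogen, not a substituent on that nitrogen. Compound 4, `CC[N+]1(CCCCCCCOc2cc(C)cc(-n3cc(C(=O)Nc4cc(F)cc(F)c4)c(=O)c4ccc(N(C)C)nc43)c2)CCCCC1`, differs from compound 3 by methyl in place of hydrogen on a saturated chain carbon bound to an amine nitrogen in a ring. Among the compounds with values here, no measured step bears on this kind of change, so for this assay no step beyond the scatter is expected in either direction, with wide uncertainty around that. The expected change is a number 4.8 percentage points lower from compound 3 to compound 4 (within the scatter). Compound 4 is accordingly expected to give 42%, in the range 15% to 65%.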

Compound 4, a percentage reported as inhibition, at one concentration (the size of the read-out at that concentration, not a potency): 67.2%
The estimate for compound 4 lay 25.2 percentage points below the measured number; the measured number lies above the stated range.
By their numbers in this assay, from the lowest: compounds 2 and 1 (each within the scatter of the next); then compound 3; then compound 4.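

In this assay, methyl to ethyl on a saturated chain carbon bound to an amine nitrogen in a ring gives a number 20.4 percentage points higher from compound 3 to compound 4 (beyond the scatter), so this tail responds to a change of the substituent on the ring nitrogen as well as to a change of ring. Combined with the six-membered ring, the ethyl group gives a number 62.9 percentage points higher from compound 2 to compound 4 (beyond the scatter), and both changes run in the same direction. Nothing available explains this rise.

On these data alone, whether a propyl or a longer chain on the ring nitrogen raises the number further remains open. So does whether ethyl on the five-membered ring would have any such effect.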